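Bulk at the saturated ring carbon: isopropyl to cyclohexyl

This account rests on a few compounds, and the source may have more. Where it says the series, first, only, none or still open, it means among the compounds named here.

Measured compounds in a functional assay for antagonist activity at Adrenergic receptor alpha-1 (Rattus norvegicus); a higher number here means weaker binding, a lower number tighter binding:
compound 1 `COc1cccc(OC)c1OCCNC[C@H]1Oc2ccccc2O[C@H]1C` gives 3.16 nM
compound 2 `COc1cccc(OC)c1OCCNC[C@H]1Oc2ccccc2O[C@H]1C(C)C` gives 1150 nM
compound 3 `COc1cccc(OC)c1OCCNC[C@H]1Oc2ccccc2O[C@@H]1C(C)C` gives 269 nM

Compound 2 stands highest of the three numbers in this assay. Its nearest neighbour is compound 3, reached by a 4.3-fold lower number from compound 2 to compound 3 (0.63 log units; beyond the scatter); the two share all atoms and bonds, and the step rests on (the fact that compounds 2 and 3 differ only in the configuration as drawn). The furthest is compound 1, separated by a 360-fold higher number from compound 1 to compound 2 (2.56 log units; beyond the scatter).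

Compound 4 `COc1cccc(OC)c1OCCNC[C@H]1Oc2ccccc2O[C@H]1C1CCCCC1` is not yet measured. Relative to compound 2 the change is cyclohexyl in place of isopropyl on a saturated ring carbon.

Of the measured steps, the one that bears most directly on this change is a 360-fold higher number from compound 1 to compound 2 (2.56 log units; beyond the scatter), where a larger group at the same saturated ring carbon brought a large rise in the number. The step of a 4.3-fold lower number from compound 2 to compound 3 (0.63 log units; beyond the scatter) concerns configuration only and speaks less to a change of group size; it does show that this position is sensitive. Since compound 4 carries a still larger group at the position that already cost compound 2 so much, a further rise in this assay is expected, though smaller than the first, as expected by a 3.0-fold higher number from compound 2 to compound 4 (0.48 log units; beyond the scatter).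

Compound 4 is therefore estimated at 3500 nM, within 900 nM to 14000 nM.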

Compound 4, dissociation constant: 631 nM
For compound 4 the middle estimate is 5.5-fold (0.74 log units) above the measured one; measured number below the stated range.
By their numbers in this assay, from the lowest: compound 1; then compound 3; then compounds 4 and 2 (each within the scatter of the next).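

Cyclohexyl in place of isopropyl on this saturated ring carbon gives a 1.8-fold lower number from compound 2 to compound 4 (0.26 log units; within the scatter) in this assay, so the larger group with its added ring cannot be told apart from isopropyl here. Within the data shown here, the steep dependence on size seen in the earlier compounds therefore does not continue in a graded way: both a 360-fold higher number from compound 1 to compound 2 (2.56 log units; beyond the scatter) and a 200-fold higher number from compound 1 to compound 4 (2.30 log units; beyond the scatter) are beyond the scatter, and among compounds 1, 2 and 4 the separation lies between methyl and the two larger groups, with no order between those two. Nothing on hand explains why the two larger groups sit together in this assay.

Still open, as far as these compounds go, is where along the way from methyl to isopropyl the number climbs, which ethyl at this carbon would begin to settle, and whether a group carrying an amine or a hydroxyl would behave like the carbon-only groups. Also open, from the compounds shown here alone, is whether the configuration effect seen with isopropyl, from compound 2 to compound 3, holds for cyclohexyl too.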